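This account rests on a few compounds, and the source may have more. Where it says the series, first, only, none or still open, it means among the compounds named here.

Working notes on the series. Compound 2 `O=C(CCCCCCc1cccnc1)c1ncc(-c2ccccn2)o1` gives 32 nM in an assay for inhibition of Fatty-acid amide hydrolase 1 (Rattus norvegicus); on this read-out lower numbers stand for stronger inhibition and higher numbers for weaker inhibition. Compound 1 `O=C(CCCCC#Cc1ccncc1)c1ncc(-c2ccccn2)o1` gives 150 nM and compound 3 `O=C(CCCCSCc1ccccc1)c1ncc(-c2ccccn2)o1` gives 25 nM. Compound 2 therefore sits second highest of the three numbers: the step of a 4.7-fold lower number from compound 1 to compound 2 (0.67 log units; beyond the scatter) lies beyond the scatter, while the step of a 1.3-fold lower number from compound 2 to compound 3 (0.11 log units; within the scatter) lies within it. Compound 4 `O=C(CCCCCS(=O)(=O)c1ccccc1)c1ncc(-c2ccccn2)o1` is not yet measured; it differs from compound 2 by phenylsulfonyl in place of (pyridin-3-yl)methyl on a saturated chain carbon, five bonds along the chain from a carbonyl carbon. Among the measured compounds shown here, no measured step bears on a phenylsulfonyl group, but the closest comparison is the step of a 1.3-fold lower number from compound 2 to compound 3 (0.11 log units; within the scatter), which was within the scatter, and the step of a 6.0-fold lower number from compound 1 to compound 3 (0.78 log units; beyond the scatter), which was modest. For compound 4 the expected step in this assay is a 1.3-fold higher number from compound 2 to compound 4 (0.10 log units; within the scatter), not beyond the scatter. Compound 4 is estimated at 40 nM, range 12 nM to 130 nM.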

Compound 4, inhibition constant: 6000 nM
The estimate for compound 4 lay 150-fold (2.18 log units) below the measured number; measured number outside the range, above it.
By their numbers in this assay, from the lowest: compounds 3 and 2 (each within the scatter of the next); then compound 1; then compound 4.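

In this assay, among the compounds shown here, the step of a 190-fold higher number from compound 2 to compound 4 (2.27 log units; beyond the scatter) is the largest, so this end of the chain does not accept every ring-bearing group alike, which the earlier steps did not reveal. The change replaces a ring with one hetero atom by a carbon-only ring and adds two double bonds outside aromatic rings, and these two parts cannot be separated here. No measurement on hand explains the loss. Still open, as far as these compounds go, is how a phenylsulfanyl group at this place would read. From the compounds shown here alone, a longer chain ending in phenylsulfonyl also remains open.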